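Pyrazine hydrazones: from methoxy to cyano on the aryl ring

The source may report more compounds than this note shows. Statements on the series, on what has been measured and on what is new or still open speak of the compounds shown alone.

Measured so far:
Compound 1, `O=C(N/N=C/c1ccccc1)c1cnccn1`: 100%
Compound 2, `COc1ccc(/C=N/NC(=O)c2cnccn2)cc1`: 74%

Of the compounds shown here, two sharing the pyrazine carbohydrazide core have been measured in an ADME assay on J774 cells (Mus musculus) for cytotoxicity, read by MTT assay, with a stated time of 48 h, tested at 50 ug/mL; on this read-out lower numbers stand for a stronger effect and higher numbers for a weaker effect at the one concentration tested. Compound 1, with an unsubstituted aryl ring, gives 100%. Within the data shown here, compound 2 gives 74%, the lower of the two numbers; the only step known, a number 26 percentage points lower from compound 1 to compound 2 (beyond the scatter), sets compound 2 apart from compound 1 by more than the scatter.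

Compound 3 is `N#Cc1ccc(/C=N/NC(=O)c2cnccn2)cc1`. It differs from compound 2 by cyano in place of methoxy on an aromatic carbon.

Among the measured compounds shown here, no measured step swaps one aryl substituent for another; the single step known, a number 26 percentage points lower from compound 1 to compound 2 (beyond the scatter), introduces methoxy where hydrogen stood and so bears on this change only at one remove. Whether cyano at the same place will sit nearer the number of compound 1 or that of compound 2 cannot be read from the data, so the expectation is a small step, possibly upward, with a wide range. Compound 3 is therefore estimated at 84% (range 62% to 100%), which would mean an expected step of a number 10 percentage points higher from compound 2 to compound 3 (within the scatter) in this assay.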

Compound 3, a percentage reported as activity, at one concentration (the size of the read-out at that concentration, not a potency): 100%
Beside the measured number, compound 3's estimate is 16 percentage points below it, within the range that was stated.
By their numbers in this assay, from the lowest: compound 2; then compounds 1 and 3 (each within the scatter of the next).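

Among these compounds, exchanging methoxy for cyano on this aromatic carbon, para to a large group, gives a number 26 percentage points higher from compound 2 to compound 3 (beyond the scatter) in this assay, the first measured swap of one substituent for another at this place. Set against hydrogen at the same carbon, cyano gives no change at the digits printed from compound 1 to compound 3 (within the scatter), so carrying a substituent here does not in itself bring the lower number: among these three compounds, only the methoxy of compound 2 stands apart, while cyano cannot be told from hydrogen in this read-out. No measurement at hand explains why methoxy and cyano part in this way.

Going by these compounds, with only these two substituents to compare, it remains open whether the lower number of compound 2 is particular to methoxy or would also appear with other groups at this place, such as an ethoxy group, a hydroxyl, an amine or a carboxylic acid. Also open, on these data alone, is whether methoxy and cyano would keep this relation on other carbons of the aryl ring, or at concentrations other than the single one tested.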